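Chalcone series: swapping the styryl aryl group

This account rests on a few compounds, and the source may have more. Where it says the series, first, only, none or still open, it means among the compounds named here.

Compound 1 `COc1ccc(/C=C/C(=O)c2cccc(-c3cccc(F)c3)c2)cc1` gives 2440 nM in a functional assay on A549 cells (Homo sapiens) for cytotoxicity, read by sulforhodamine B assay, with a stated time of 48 h (on this read-out lower numbers stand for stronger inhibition and higher numbers for weaker inhibition), the higher of the two numbers at hand; compound 2 `COc1ccc(/C=C/C(=O)c2cccc(-c3cccc(F)c3)c2)cc1O` gives 500 nM, and the step of a 4.9-fold lower number from compound 1 to compound 2 (0.69 log units; beyond the scatter) is the only measured one. Compound 3 `O=C(/C=C/c1cccc(Br)c1)c1cccc(-c2cccc(F)c2)c1` differs from compound 1 as follows: 3-bromophenyl in place of 4-methoxyphenyl on a double-bonded chain carbon bound to a double-bonded chain carbon. The measured step concerns a different part of the core and does not bear on this change, so no step beyond the scatter is expected in this assay and the estimate is held wide. Compound 3 is estimated at 3500 nM, range 1000 nM to 12000 nM, a step of a 1.4-fold higher number from compound 1 to compound 3 (0.16 log units; within the scatter).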

Compound 3, half-maximal inhibitory concentration: 9120 nM
Beside the measured number, compound 3's estimate is 2.6-fold (0.42 log units) below it, within the range that was stated.
By their numbers in this assay, from the lowest: compound 2; then compound 1; then compound 3.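

In this assay the aryl group on a double-bonded chain carbon bound to a double-bonded chain carbon proves responsive: 3-bromophenyl in place of 4-methoxyphenyl gives a 3.7-fold higher number from compound 1 to compound 3 (0.57 log units; beyond the scatter) and so moves the number in the opposite direction to the hydroxy step. This single change swaps the substituent and its placement together, so the two cannot be told apart. Nothing at hand explains the step. Open, going by these compounds, is how 3-methoxyphenyl or 4-bromophenyl would read here, which would separate substituent from placement, and how a 4-dimethylaminophenyl group would fare on the same carbon.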